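Enantiomer Swap in a Benzamide Series at Dopamine D4

The source may hold more compounds than are shown below. What is called first, only, known or untested is meant among the compounds shown, and "the series" means these compounds.

Compound 1 `COc1cc(N)c(Cl)cc1C(=O)NC[C@@H]1CCN(Cc2ccccc2)C1` — 180 nM
Compound 2 `COc1ccc(Br)cc1C(=O)NC[C@@H]1CCN(Cc2ccccc2)C1` — 48 nM

In an assay on isolated protein for binding affinity to D(4) dopamine receptor (Homo sapiens) (a higher number here means a weaker inhibitor, a lower number a stronger inhibitor), compound 1 gives 180 nM, and compound 2 gives 48 nM. Compound 1 therefore stands with the higher of the two numbers, and the gap between them is beyond the usual scatter. For the measured compounds named here, no step is recorded between compound 1 and compound 2, so their values can only be set side by side.

Compound 3 `COc1cc(N)c(Cl)cc1C(=O)NC[C@H]1CCN(Cc2ccccc2)C1` has not yet been tested in this assay. It differs from compound 1 in configuration alone: the two compounds have the same atoms and bonds and differ only in configuration as drawn: 1 of 1 stereo elements differ; a stereocentre at a saturated ring carbon is drawn S in compound 1 and R in compound 3. Going by the values given here, nothing among the measured compounds shows how such a swap of handedness plays out here, so no direction can be read from them. Mirror-image pairs often do separate, but the side that gains cannot be inferred. The estimate for compound 3 is therefore close to compound 1, at 220 nM with a wide range from 35 nM to 1400 nM, expected as a step of a 1.2-fold higher number from compound 1 to compound 3 (0.09 log units; within the scatter).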

Compound 3, inhibition constant: 140 nM
The estimate for compound 3 lay 1.6-fold (0.20 log units) above the measured number; the measured number falls inside the stated range.
By their numbers in this assay, from the lowest: compound 2; then compounds 3 and 1 (each within the scatter of the next).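

Turning the stereocentre at the saturated ring carbon from S to R gives a 1.3-fold lower number from compound 1 to compound 3 (0.11 log units; within the scatter), so in this assay this pair of mirror-image forms cannot be told apart. The earlier compounds shown here offered no view of handedness at this carbon, and here, at least for this substitution on the benzamide, the drawn configuration makes no difference that can be read beyond ordinary measurement noise. For the compounds shown here, the comparison is a clean one because only one feature separates the pair: the fact that compounds 1 and 3 differ only in the configuration as drawn.

It remains open whether the two forms would stay this close with the bromine-bearing benzamide of compound 2, whose mirror image is not among the compounds shown. From the compounds shown here alone, it is equally open whether they would stay close if the benzyl group gave way to a longer chain, such as phenethyl.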